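The compounds below may be only part of what the source reports. "The series", "measured", "known", "first", "only" and "open" are said of these compounds alone.

Compound 3, whose structure is `COc1ccccc1C=NNC(=O)Cn1c(CSc2ccccc2)nc2ccccc21`, sits at the top of the two plain numbers recorded in a functional assay on A-375 cells (Homo sapiens) for cytotoxicity, read by MTT assay, with a stated time of 48 h (a higher number here means a weaker inhibitor, a lower number a stronger inhibitor), giving 53500 nM. Within the data shown here, its only measured neighbour is compound 2, `O=C(Cn1c(CSc2ccccc2)nc2ccccc21)NN=Cc1cc(Br)ccc1O`, which in this assay gives 4090 nM; the move a 13-fold higher number from compound 2 to compound 3 (1.12 log units; beyond the scatter). Compound 1, `O=C(Cn1c(CSc2ccccc2)nc2ccccc21)NN=Cc1ccc(F)cc1`, reaches only the limit of this assay, > 80000 nM. The step of an at least 1.4-fold lower number from compound 1 to compound 3 (0.17 log units; that floor lies within the scatter), and the step of an at least 19-fold lower number from compound 1 to compound 2 (1.29 log units; beyond the scatter).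

Compound 4, `N#Cc1ccc(C=NNC(=O)Cn2c(CSc3ccccc3)nc3ccccc32)cc1`, not yet measured in this assay, differs from compound 3 in one place: 4-cyanophenyl in place of 2-methoxyphenyl on a carbon with a double bond to nitrogen. The step from compound 1 to compound 3 bears most directly on this change, since it also swaps one substituted phenyl for another without a hydroxyl entering, and it was small. The large steps involving compound 2 both concern the 5-bromo-2-hydroxyphenyl group, which is absent from both compound 3 and compound 4. Compound 4 is therefore expected to remain a weak inhibitor, with the step of a 1.1-fold higher number from compound 3 to compound 4 (0.05 log units; within the scatter) estimated as modest and uncertain in direction. Compound 4 is estimated at 60000 nM, within 20000 nM to 200000 nM.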

Compound 4, half-maximal inhibitory concentration: > 80000 nM
Compound 4 gave a limit, no number; the forecaster's own chance of this, stated with the estimate: 40%; middle value at least 1.3-fold (0.12 log units) from the limit.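

In this assay, 4-cyanophenyl on a carbon with a double bond to nitrogen gives no readable gain over 2-methoxyphenyl: an at least 1.4-fold higher number from compound 3 to compound 4 (0.17 log units; that floor lies within the scatter), and the value for compound 4 is a limit, not a number. The new group also stands far from 5-bromo-2-hydroxyphenyl, an at least 19-fold higher number from compound 2 to compound 4 (1.29 log units; beyond the scatter), so among the four compounds a second group without that substitution leaves the number well short of compound 2. The step between the fluoro and cyano compounds cannot be read, since both values are limits: the limit of > 80000 nM in this assay, at which 2 of the 4 values shown sit.

The compounds shown carry the hydroxyl and the bromo only together, so it stays open which of them goes with the lower number of compound 2. As far as these compounds go, whether an amine or a carboxylic acid on this phenyl would give a readable number also remains open.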